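Replacing the Aryl Group of Compound 1

The source may hold more compounds than are shown below. What is called first, only, known or untested is meant among the compounds shown, and "the series" means these compounds.

In a functional assay on MCF7 cells (Homo sapiens) for cytotoxicity, read by MTT assay, with a stated time of 72 h (a higher number here means a weaker inhibitor, a lower number a stronger inhibitor), compound 1 `Cc1cccc(NC(=O)CSC(=S)N[C@H]2CCOC2=O)c1` gives 63200 nM and stands highest of the two numbers measured, while compound 2 `O=C(CSC(=S)N[C@H]1CCOC1=O)Nc1cccc([N+](=O)[O-])c1` gives 5460 nM on the same core. Compound 3 `O=C(CSC(=S)N[C@H]1CCOC1=O)Nc1ccc(F)cc1` has 4-fluorophenyl in place of 3-methylphenyl on an amide-type nitrogen. Within the data shown here, the one measured step bearing on this is nitro in place of methyl on an aromatic carbon (a 12-fold lower number from compound 1 to compound 2 (1.06 log units; beyond the scatter)), which is large and beyond the scatter but brings in a different group. A smaller step in the same direction is therefore expected in this assay (estimated a 3.2-fold lower number from compound 1 to compound 3 (0.50 log units; beyond the scatter)). Compound 3 is thus expected at 20000 nM (estimated range 6000 nM to 65000 nM).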

Compound 3, half-maximal inhibitory concentration: 5830 nM
Beside the measured number, compound 3's estimate is 3.4-fold (0.54 log units) above it; measured number outside the range, below it.
By their numbers in this assay, from the lowest: compounds 2 and 3 (each within the scatter of the next); then compound 1.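

In this assay, 4-fluorophenyl in place of 3-methylphenyl on an amide-type nitrogen gives an 11-fold lower number from compound 1 to compound 3 (1.04 log units; beyond the scatter), so a large step at this position is not confined to the nitro group of compound 2. Compound 2 and compound 3 lie within the scatter of each other, and compound 1 stands apart from both. The data offer no measurement that explains this step. From the compounds shown here alone, it remains open where an unsubstituted phenyl, or a cyclohexyl on the same nitrogen, would fall. Going by these compounds, the effect of a methoxy or an amine on the aromatic ring also remains open.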